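From Compound 3 to Compound 4: Losing the Methoxy

A few compounds are considered here, and "the series" means these few. Any claim that something is new, unique, unknown or untested is made for them only; others in the source may bear on it.

Measured in an ADME assay on Vero cells (Chlorocebus sabaeus) for cytotoxicity, read by MTT assay, with a stated time of 72 h; a higher number here means that more compound is tolerated, a lower number that less compound is tolerated:
- compound 1 `COc1ccccc1[C@H](O)COC(=O)/C=C/c1ccccc1`: 14000 nM
- compound 2 `COc1cccc([C@H](O)COC(=O)/C=C/c2ccccc2)c1`: 61900 nM
- compound 3 `COc1ccc([C@H](O)COC(=O)/C=C/c2ccccc2)cc1`: 33500 nM

Compound 3 at 33500 nM cannot be told apart from compound 2 at 61900 nM, since their gap lies within the scatter. Compound 1 at 14000 nM falls lower than compound 3, beyond the scatter.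

Compound 4 `O=C(/C=C/c1ccccc1)OC[C@@H](O)c1ccccc1` has hydrogen in place of methoxy on an aromatic carbon, para to a large group (hydrogen in place of methoxy on an aromatic carbon). Among the measured compounds shown here, all three measured compounds carry a methoxy, so no measured pair shows the effect of losing it. The expected change in this assay is therefore none beyond the scatter, an estimated 1.0-fold higher number from compound 3 to compound 4 (0.02 log units; within the scatter). For compound 4 the expected value is 35000 nM, with an estimated range of 14000 nM to 85000 nM.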

Compound 4, half-maximal cytotoxic concentration: 39200 nM
Compound 4: middle estimate off by 1.1-fold (0.05 log units), on the low side, and the stated range covers the measured number.
By their numbers in this assay, from the lowest: compound 1; then compounds 3, 4 and 2 (each within the scatter of the next).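

In this assay, hydrogen in place of methoxy on the aromatic carbon para to a large group stays within the scatter (a 1.2-fold higher number from compound 3 to compound 4 (0.07 log units; within the scatter)), and a second such step also stays within it (a 1.6-fold lower number from compound 2 to compound 4 (0.20 log units; within the scatter)). Only the third step goes beyond the scatter (a 2.8-fold higher number from compound 1 to compound 4 (0.45 log units; beyond the scatter)), so among these compounds, removing the methoxy makes a clear difference in just one case. Nothing available explains why that case differs. As far as these compounds go, it remains open whether a chlorine atom, an amine or a longer chain such as ethoxy on this ring would also leave the number within the scatter.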